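Ethoxy in Place of Fluoro: Compound 1 to Compound 3

The source may hold more compounds than are shown below. What is called first, only, known or untested is meant among the compounds shown, and "the series" means these compounds.

Compound 1 `CC1CC/C(=N\Nc2ccccc2F)c2ncc(C(=O)O)c(=O)n21` was tested in a functional assay on the whole organism for inhibition, with Rattus norvegicus as the target; a higher number here means that more compound is needed for the effect, a lower number that less compound is needed. In this assay compound 1 gives only a limit, > 1000 umol/kg, and no number. Compound 2 `CC1CC/C(=N\Nc2cccc(Cl)c2)c2ncc(C(=O)O)c(=O)n21` carries 3-chlorophenyl in place of 2-fluorophenyl on an amine nitrogen. In this assay compound 2 likewise gives a limit, > 100 umol/kg. The step that the two limits leave unreadable from compound 1 to compound 2 cannot be read, since the limit of > 100 umol/kg in this assay, at which 1 of the 2 values shown sits, and the limit of > 1000 umol/kg in this assay, at which 1 of the 2 values shown sits, are the only two marks and neither fixes a size.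

Compound 3 `CCOc1ccccc1N/N=C1\CCC(C)n2c1ncc(C(=O)O)c2=O` differs from compound 1 by ethoxy in place of fluoro on an aromatic carbon. Going by the values given here, no measured step involves an ethoxy group, and the single step that has been measured, the change from 2-fluorophenyl to 3-chlorophenyl, remains unreadable. Nothing measured therefore bears on this change beyond the two limits. The step expected here, a number no higher from compound 1 to compound 3 (the limit leaves the size open), would most likely leave the new compound at a limit as well. Compound 3 is therefore expected to give about 1000 umol/kg in this assay, within a range from 300 umol/kg to 3000 umol/kg, with a real chance that only a limit is reported.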

Compound 3, dose for 50% inhibition: > 1000 umol/kg
Compound 3: only a limit was reported; the forecaster's own chance of this, stated with the estimate: 70%; the middle value sits exactly at the limit.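

In this assay compound 3 gives only a limit, > 1000 umol/kg. Going by these compounds alone, compound 1 likewise gives only a limit, > 1000 umol/kg, so no step between compound 1 and compound 3 can be read. The compounds shown leave open what dose any of them needs for the effect, and whether ethoxy and fluoro differ at all.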